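Racemate versus single enantiomer in a sulfonamide series

The source may hold more compounds than are shown below. What is called first, only, known or untested is meant among the compounds shown, and "the series" means these compounds.

Measured compounds: compound 1 `Nc1ccccc1S(=O)(=O)N1CC(n2cnc3c(Cl)nc(Cl)nc32)OCc2ccccc21` gives 467 nM; compound 2 `O=[N+]([O-])c1ccc(S(=O)(=O)N2C[C@@H](n3cnc4c(Cl)nc(Cl)nc43)OCc3ccccc32)cc1` gives 110 nM; compound 3 `COC(CN(c1ccccc1CO)S(=O)(=O)c1ccc([N+](=O)[O-])cc1)n1cnc2c(Cl)nc(Cl)nc21` gives 409 nM.

In a functional assay on MDA-MB-231 cells (Homo sapiens) for cytotoxicity, read by sulforhodamine B assay, with a stated time of 3 days (a higher number here means a weaker inhibitor, a lower number a stronger inhibitor), compound 2 has the lowest number of the three, with compound 3 nearest and compound 1 furthest, both beyond the scatter. Compound 4 `O=[N+]([O-])c1ccc(S(=O)(=O)N2CC(n3cnc4c(Cl)nc(Cl)nc43)OCc3ccccc32)cc1` is related to compound 2 by the two compounds have the same atoms and bonds; at least one stereo element is drawn with a configuration in one of them and without one in the other: 1 of 1 stereo elements differ; a stereocentre at a saturated ring carbon is drawn S in compound 2 and without a configuration in compound 4; the two compounds have the same atoms and bonds, only the drawn configuration differs. Among the compounds with values here, with no pair of measured compounds differing in a single place, no step can be taken from the data. One expects for compound 4 a small shift toward a higher number, within or just beyond the scatter, as a 1.5-fold higher number from compound 2 to compound 4 (0.19 log units; within the scatter). Compound 4 is estimated at 170 nM, between 90 nM and 400 nM.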

Compound 4, half-maximal inhibitory concentration: 166 nM
The estimate for compound 4 lay 1.0-fold (0.01 log units) above the measured number; the range from low to high includes it.
By their numbers in this assay, from the lowest: compounds 2 and 4 (each within the scatter of the next); then compounds 3 and 1 (each within the scatter of the next).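

In this assay, compounds 2 and 4 stand together (a 1.5-fold higher number from compound 2 to compound 4 (0.18 log units; within the scatter)), so a defined configuration at the saturated ring carbon gives no separation from the form drawn without one, and the pair differs only in this: (the fact that one of compounds 2 and 4 is drawn with a defined configuration and the other without, at the place where they differ). Within the data shown here, the same result gives the first readable step at the sulfonyl sulfur, where 4-nitrophenyl takes the place of 2-aminophenyl (a 2.8-fold lower number from compound 1 to compound 4 (0.45 log units; beyond the scatter)).

Still open, going by these compounds, is how a compound drawn R at that carbon would stand. Also open, on these data alone, is whether the step follows the nitro group or its place on the ring, as a 4-aminophenyl or 2-nitrophenyl group would show.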